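A few compounds are considered here, and "the series" means these few. Any claim that something is new, unique, unknown or untested is made for them only; others in the source may bear on it.

In an ADME assay on microsomes from liver (Rattus norvegicus) for metabolic stability, using NADPH, with a stated time of 30 min (on this read-out lower numbers stand for a less stable compound and higher numbers for a more stable compound), compound 1 (`Cc1nc(C)c(-c2csc(Nc3ccc(C(=O)N4C5CNCC4COC5)cn3)n2)s1`) gives 71.5% and compound 2 (`COC(=O)N1CC2CCCC(C1)N2C(=O)c1ccc(Nc2nc(-c3sc(C)nc3C)cs2)nc1`) gives 43.8%. Compound 1 therefore holds the higher of the two numbers, and the gap between them lies beyond the usual scatter of repeat measurements.

Compound 3 (`COC(=O)N1CCN(C(=O)c2ccc(Nc3nc(-c4sc(C)nc4C)cs3)nc2)CC1`) has not yet been measured. It keeps the core of compound 1 and changes only the group on a carbonyl carbon: a group of 10 heavy atoms (6 carbon, 2 nitrogen, 2 oxygen; one six-membered non-aromatic ring with 2 hetero atoms) in place of a group of 9 heavy atoms (6 carbon, 2 nitrogen, 1 oxygen; 2 six-membered non-aromatic rings with 2 hetero atoms each), on a carbonyl carbon. In words, a 4-(methoxycarbonyl)piperazin-1-yl group, with one six-membered non-aromatic ring, takes the place of a group with two such rings.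

Among the measured compounds shown here, no two measured compounds differ in just one place, so any forecast here is rough. The closest guide is compound 2 at 43.8%, which also carries a methoxycarbonyl group, so a result nearer to that of compound 2 is expected. In this assay, the estimated change is a number 21.5 percentage points lower from compound 1 to compound 3 (beyond the scatter), a fall expected to lie beyond the scatter. Compound 3 is expected to give 50%, with an estimated range of 30% to 70%.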

Compound 3, percent of the compound remaining: 77.9%
The estimate for compound 3 lay 27.9 percentage points below the measured number; measured number above the stated range.
By their numbers in this assay, from the lowest: compound 2; then compounds 1 and 3 (each within the scatter of the next).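

In this assay, placing a 4-(methoxycarbonyl)piperazin-1-yl group on the carbonyl carbon, in place of the group with two six-membered non-aromatic rings, gives a number 6.4 percentage points higher from compound 1 to compound 3 (within the scatter), so this read-out cannot tell the two compounds apart. The swap removes one of those rings and the hydrogen-bond donor of the departing group, and it adds a double bond outside aromatic rings, yet the percentage remaining stays within the scatter; for this one pair, then, neither the second ring nor that donor is needed to keep a number of this size. Nothing measured alongside this result bears on why the two compounds match.

Whether the methoxycarbonyl group itself matters stays open: the compounds shown include no plain piperazin-1-yl group, no 4-acetylpiperazin-1-yl group and no morpholine on the same carbonyl carbon. Also open, on these data alone, is whether this match would hold with changes elsewhere on the shared core, as this one pair differs only in the group on the carbonyl carbon.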